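The source may report more compounds than this note shows. Statements on the series, on what has been measured and on what is new or still open speak of the compounds shown alone.

Compound 1 `O=C(c1cccc(Cl)c1)c1ccc(O)c(O)c1` and compound 2 `Oc1cc(Br)c(Cc2ccccc2)cc1O` have been measured in a functional assay on HUVEC cells (Homo sapiens); a lower number here means that less compound is needed, a higher number that more compound is needed for the effect. Compound 1 gives 5000 nM in this assay. Compound 2 gives 12200 nM in this assay, the higher of the two numbers; the gap down to compound 1 is beyond the scatter. Within the data shown here, compound 1 and compound 2 differ in more than one place, so no single step between them is counted; their two values show only that the pair spans a gap wider than the scatter.

Compound 3 `Oc1cc(Cc2ccccc2)c(Br)c(Br)c1O` is not yet measured. It differs from compound 2 by bromo in place of hydrogen on an aromatic carbon. Among the measured compounds shown here, no comparable step exists among the measured compounds. The step expected here, a 1.2-fold lower number from compound 2 to compound 3 (0.09 log units; within the scatter), is small, in no firm direction, and likely within the scatter. Compound 3 is therefore expected to give about 10000 nM in this assay, with a range from 4000 nM to 30000 nM.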

Compound 3, half-maximal effective concentration: 3900 nM
Estimate against measurement, compound 3: 2.6-fold (0.41 log units) above, and the stated range ends above it.
By their numbers in this assay, from the lowest: compounds 3 and 1 (each within the scatter of the next); then compound 2.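

In this assay, bromo in place of hydrogen on this aromatic carbon, ortho to a bromo group and ortho to a hydroxy group, gives a 3.1-fold lower number from compound 2 to compound 3 (0.50 log units; beyond the scatter). This carbon is therefore not indifferent to substitution: adding a second bromo to the ring of compound 2 changes the number by more than the scatter, although the step is modest and rests on this one pair. No measurement at hand accounts for the step.

As far as these compounds go, whether the lower number belongs to bromo in particular stays open, since chloro, methyl or an amine on this same carbon would be needed to tell. Also open, from the compounds shown here alone, is whether the same change carries over to the core of compound 1, which has a carbonyl where compound 2 has its methylene.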